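A few compounds are considered here, and "the series" means these few. Any claim that something is new, unique, unknown or untested is made for them only; others in the source may bear on it.

Of the compounds shown here, three built on the shared core have been tested. Compound 1 `COc1ccc(C)cc1NC(=S)N/N=C/c1ccc2ccccc2n1` sits at the limit of a functional assay on HT-29 cells (Homo sapiens) for antiproliferative activity, read by sulforhodamine B assay, with a stated time of 72 h (on this read-out higher numbers stand for weaker inhibition and lower numbers for stronger inhibition), where compound 1 gives > 100000 nM, a limit rather than a number (the limit of > 100000 nM in this assay, at which 1 of the 3 values shown sits). Compound 3 `NC(=S)N/N=C/c1cc2ccccc2s1` gives 99200 nM in this assay. Compound 2 `Fc1cccc(NC(=S)N/N=C/c2ccc3ccccc3n2)c1` gives 74700 nM in this assay, the lower of the two numbers, though its gap to compound 3 lies within the usual scatter, so the two cannot be ranked against each other. Compound 4 `N#Cc1ccc(NC(=S)N/N=C/c2ccc3ccccc3n2)cc1` differs from compound 2 in one place: 4-cyanophenyl in place of 3-fluorophenyl on an amide-type nitrogen. Within the data shown here, no measured pair covers such an exchange, so its size cannot be read from the data. The step from compound 2 to compound 4 is expected to be a 1.1-fold lower number from compound 2 to compound 4 (0.06 log units; within the scatter), nothing beyond the scatter. Compound 4 is estimated at 65000 nM, with a range from 20000 nM to 200000 nM.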

Compound 4, half-maximal inhibitory concentration: 15600 nM
Estimate against measurement, compound 4: 4.2-fold (0.62 log units) above; measured number below the stated range.
By their numbers in this assay, from the lowest: compound 4; then compounds 2 and 3 (each within the scatter of the next). At a limit, above all of these: compound 1.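

On this amide-type nitrogen, the aryl group can move the number: 4-cyanophenyl in place of 3-fluorophenyl gives a 4.8-fold lower number from compound 2 to compound 4 (0.68 log units; beyond the scatter) in this assay, the only step shown so far. The two groups differ both in their substituent and in where it sits on the ring, so this single step cannot separate those two changes. Nothing shown accounts for the size of this step.

Going by these compounds, it remains open how a 3-cyanophenyl or a 4-fluorophenyl group on this nitrogen would read. On these data alone, a 4-carboxyphenyl group is equally open.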